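This account rests on a few compounds, and the source may have more. Where it says the series, first, only, none or still open, it means among the compounds named here.

Measured in an ADME assay on A549 cells (Homo sapiens) for cytotoxicity, read by fluorescence, with a stated time of 48 h; on this read-out higher numbers stand for weaker inhibition and lower numbers for stronger inhibition:

compound 1 `COc1cc(Cc2cnc(N)nc2N)cc(Cl)c1OC`: 467000 nM
compound 2 `COc1cc(Cc2cnc(N)nc2N)cc(I)c1OC`: 266000 nM

Within the data shown here, compound 2, at 266000 nM, stands within the scatter of compound 1, the only other compound measured so far in this assay. The next compound is compound 3 `COc1cc(Cc2cnc(N)nc2N)cc(Br)c1OC`, which is related to compound 2 by one change: bromo in place of iodo on an aromatic carbon. In words, this is bromo in place of iodo on an aromatic carbon, while the rest of the structure stays the same.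

A single measured step bears on this change, the exchange of iodo in place of chloro on an aromatic carbon. It amounts to a 1.8-fold lower number from compound 1 to compound 2 (0.24 log units; within the scatter). As that step stayed small, no step beyond the scatter is expected in this assay for the exchange of iodo for bromo. The estimate is therefore placed inside the small span of the two measured values, and the range allows for the scatter of the assay. The estimate corresponds to an expected 1.3-fold higher number from compound 2 to compound 3 (0.12 log units; within the scatter). Compound 3 is estimated at 350000 nM, with an expected range from 200000 nM to 600000 nM.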

Compound 3, half-maximal inhibitory concentration: 321000 nM
For compound 3 the middle estimate is 1.1-fold (0.04 log units) above the measured one; the measured number falls inside the stated range.
By their numbers in this assay, from the lowest: compounds 2, 3 and 1 (each within the scatter of the next).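

With bromo on this aromatic carbon, ortho to a methoxy group and meta to a group of 9 heavy atoms, chloro, bromo and iodo can now be compared at one place in this assay and the exchange of iodo for bromo gives a 1.2-fold higher number from compound 2 to compound 3 (0.08 log units; within the scatter) while the exchange of chloro for bromo gives a 1.5-fold lower number from compound 1 to compound 3 (0.16 log units; within the scatter) and both steps lie within the scatter. Together with the earlier exchange of iodo for chloro, this means that no pair among these three compounds is separated by the read-out, so no order of the three halogens can be claimed at this position. Nothing available explains why these exchanges stay so small, and no cause can be offered for it.

Whether an amine, a hydroxyl group or a nitrile on this same aromatic carbon would give a step beyond the scatter remains open, since all three compounds shown carry a halogen there. Also open, on these data alone, is whether these halogen exchanges would stay as small if a methoxy group of the shared core gave way to a longer chain such as propoxy.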